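Naphthalenyl to Dichlorobenzyl on the Amine Nitrogen

This account rests on a few compounds, and the source may have more. Where it says the series, first, only, none or still open, it means among the compounds named here.

Three compounds have been measured in an assay on HEK293 cells for displacement of a labelled ligand from Urotensin-2 receptor (Homo sapiens); on this read-out higher numbers stand for weaker inhibition and lower numbers for stronger inhibition:

Compound 1 `Cc1ccc2scc(CCC(=O)N3CCC[C@H](c4ccccc4)[C@@H]3CN3CCCC3)c2c1`: 3160 nM
Compound 2 `O=C(CN(CC1CC1)c1ccc(Cl)c(Cl)c1)N1CCC[C@H](c2ccccc2)[C@@H]1CN1CCCC1`: 50.1 nM
Compound 3 `CN(CC(=O)N1CCC[C@H](c2ccccc2)[C@@H]1CN1CCCC1)c1ccc2ccccc2c1`: 158 nM

Compound 3 stands second highest of these three numbers. Compound 2 gives a lower number, and the gap between them is beyond the scatter; compound 1 gives a higher number, and that gap too is beyond the scatter. Within the data shown here, the three compounds share one core and differ in the side chain attached to the amide, so no single-point step between any two measured compounds can be drawn.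

Compound 4 `CN(CC(=O)N1CCC[C@H](c2ccccc2)[C@@H]1CN1CCCC1)Cc1ccc(Cl)c(Cl)c1` has not yet been measured. It differs from compound 3 in one place: 3,4-dichlorobenzyl in place of naphthalen-2-yl on an amine nitrogen. Among the measured compounds shown here, compound 2 also carries a 3,4-dichlorophenyl group on its amine nitrogen, though with a different partner group, and gives 50.1 nM, which gives some footing but no direct step. In this assay compound 4 is estimated to land near 200 nM, with a range from 50 nM to 800 nM. That estimate means a step of a 1.3-fold higher number from compound 3 to compound 4 (0.10 log units; within the scatter), expected to stay within the usual scatter rather than a clear move in either direction.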

Compound 4, inhibition constant: 3980 nM
Beside the measured number, compound 4's estimate is 20-fold (1.30 log units) below it; the whole stated range lies below it.
By their numbers in this assay, from the lowest: compound 2; then compound 3; then compounds 1 and 4 (each within the scatter of the next).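

In this assay, putting 3,4-dichlorobenzyl in place of naphthalen-2-yl on this amine nitrogen gives a 25-fold higher number from compound 3 to compound 4 (1.40 log units; beyond the scatter), so this position is sensitive to the group it carries. By simple counts the swap looks modest: the two groups are close in heavy-atom count, one aromatic ring replaces two, and neither group has hydrogen-bond donors, hydrogen-bond acceptors or a net charge. Nothing available here accounts for the large step, so only its size is established.

From the compounds shown here alone, this one step changes the number of aromatic rings, adds two chlorines and adds a carbon between the ring and the nitrogen, so the contribution of each remains open. A naphthalen-2-ylmethyl group or an unsubstituted benzyl group on the same nitrogen would help separate these contributions.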